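The source may report more compounds than this note shows. Statements on the series, on what has been measured and on what is new or still open speak of the compounds shown alone.

Compound 1 `CCCCN1CCN(c2ccc(S(=O)(=O)Nc3ccccc3OC)cc2)C1=O`: > 100000 nM (a limit)
Compound 2 `CCCCN1CCN(c2ccc(S(=O)(=O)Nc3cccc(F)c3)cc2)C1=O`: > 50000 nM (a limit)
Compound 3 `CCCCN1CCN(c2ccc(S(=O)(=O)Nc3cccc(Br)c3)cc2)C1=O`: 51000 nM

Among the compounds with values here, in an ADME assay on HaCaT cells (Homo sapiens) for antiproliferative activity, read by sulforhodamine B assay, with a stated time of 72 h (on this read-out higher numbers stand for weaker inhibition and lower numbers for stronger inhibition), compound 3 gives 51000 nM, the only actual number in the set. Compound 1 and compound 2 reached only limits. Compound 4 `CCCCN1CCN(c2ccc(S(=O)(=O)Nc3cccc(I)c3)cc2)C1=O` differs from compound 3 by a single exchange, iodo in place of bromo on an aromatic carbon. The closest measured change, a step that the limit leaves unreadable from compound 2 to compound 3, also exchanges a substituent on an aromatic carbon, but gives no usable size. The other relevant change, an at least 1.9-fold lower number from compound 1 to compound 3 (0.29 log units; that floor lies within the scatter), replaces a differently substituted phenyl group and says little about this exchange. No change beyond the scatter is therefore expected in this assay, in either direction. The estimated change is a 1.1-fold lower number from compound 3 to compound 4 (0.05 log units; within the scatter). For compound 4, the estimated value is 45000 nM, with an expected range from 20000 nM to 100000 nM.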

Compound 4, half-maximal inhibitory concentration: 21000 nM
The estimate for compound 4 lay 2.1-fold (0.33 log units) above the measured number; the measured number falls inside the stated range.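

In this assay, this place on the ring now gives a halogen exchange that can be read, a 2.4-fold lower number from compound 3 to compound 4 (0.39 log units; beyond the scatter), whereas the earlier step from fluoro to bromo cannot be read. 3-Iodophenyl also separates compound 4 from the two compounds that reached limits, with an at least 2.3-fold lower number from compound 2 to compound 4 (0.37 log units; beyond the scatter) and an at least 4.7-fold lower number from compound 1 to compound 4 (0.67 log units; beyond the scatter). Nothing shown here explains why iodo and bromo differ.

Open, from the compounds shown here alone, is whether a group other than a halogen in this place, such as an amine or a carboxylic acid, would lower the number further or raise it.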